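Aryl swap on the saturated ring carbon

The source may hold more compounds than are shown below. What is called first, only, known or untested is meant among the compounds shown, and "the series" means these compounds.

Compound 1 `COc1cc(C2=NN(C(C)=O)C(c3cccc(OC)c3OC)O2)cc(OC)c1OC` gives 3.8% in a functional assay on BGC-823 cells (Homo sapiens) for antiproliferative activity, read by MTT assay, tested at 1 uM; on this read-out higher numbers stand for a stronger effect at the one concentration tested and lower numbers for a weaker effect. Compound 2 `COc1cc(C2=NN(C(C)=O)C(c3ccc(C(F)(F)F)cc3)O2)cc(OC)c1OC` gives 4.2% in this assay. Going by the values given here, the only step measured so far, a number 0.4 percentage points higher from compound 1 to compound 2 (within the scatter), lies within the scatter; compound 2 and compound 1 thus sit at one level, and neither can be called the stronger. Compound 3 `COc1cc(C2=NN(C(C)=O)C(c3ccccc3F)O2)cc(OC)c1OC` differs from compound 2 by 2-fluorophenyl in place of 4-(trifluoromethyl)phenyl on a saturated ring carbon. Among the compounds with values here, the single step bearing on this change, a number 0.4 percentage points higher from compound 1 to compound 2 (within the scatter), was within the scatter, so no step beyond the scatter is expected here either, a number 0.3 percentage points higher from compound 2 to compound 3 (within the scatter). Compound 3 is therefore estimated at 4.5%, with a range from 0% to 15%.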

Compound 3, a percentage reported as inhibition, at one concentration (the size of the read-out at that concentration, not a potency): 29.6%
Compound 3: middle estimate off by 25.1 percentage points, on the low side; measured number outside the range, above it.
By their numbers in this assay, from the lowest: compounds 1 and 2 (each within the scatter of the next); then compound 3.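

Replacing 4-(trifluoromethyl)phenyl with 2-fluorophenyl on the saturated ring carbon gives a number 25.4 percentage points higher from compound 2 to compound 3 (beyond the scatter) in this assay, and replacing 2,3-dimethoxyphenyl with 2-fluorophenyl gives a number 25.8 percentage points higher from compound 1 to compound 3 (beyond the scatter). This position therefore responds to the choice of aryl group, which the earlier pair alone did not show. No measurement at hand accounts for the rise.

Still open, on these data alone, is whether the fluorine itself matters, which a plain phenyl on this carbon would test. Also open, as far as these compounds go, is what a phenyl carrying an amine or a carboxylic acid would give.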